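Moving from pyridin-2-yl to pyridin-3-yl on the carbonyl

The source may hold more compounds than are shown below. What is called first, only, known or untested is meant among the compounds shown, and "the series" means these compounds.

Measured so far in a physicochemical assay for solubility (a higher number here means a more soluble compound, a lower number a less soluble compound), are these:
- compound 1 `CN(C)c1ccc(C(=O)N2CCC(NS(=O)(=O)c3cc(S(=O)(=O)c4ccccc4)ccc3C(F)(F)F)CC2)cc1` gives 50000 nM in this assay
- compound 2 `O=C(c1ccccn1)N1CCC(NS(=O)(=O)c2cc(S(=O)(=O)c3ccccc3)ccc2C(F)(F)F)CC1` gives 100000 nM in this assay

Within the data shown here, only one measured step is available, and it reads a 2.0-fold higher number from compound 1 to compound 2 (0.30 log units; within the scatter) for the change of pyridin-2-yl in place of 4-(dimethylamino)phenyl on a carbonyl carbon. Among the measured compounds shown here, compound 2 therefore stands within the scatter of compound 1, the only other number.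

The next structure is compound 3 `O=C(c1cccnc1)N1CCC(NS(=O)(=O)c2cc(S(=O)(=O)c3ccccc3)ccc2C(F)(F)F)CC1` with pyridin-3-yl in place of pyridin-2-yl on a carbonyl carbon. The two have the same atoms, joined differently, and the full count is pyridin-3-yl in place of pyridin-2-yl on a carbonyl carbon for this change.

For the measured compounds named here, no measured step swaps one pyridinyl for another. Going by the values given here, the single step at this carbonyl carbon is the one from compound 1 to compound 2, and it did not leave the scatter. No step beyond the scatter is therefore expected in this assay and no firm direction can be given. The expected size is a 1.3-fold lower number from compound 2 to compound 3 (0.10 log units; within the scatter) and this remains a small step. Compound 3 is estimated at 80000 nM with an expected range of 35000 nM to 160000 nM for a measurement in this assay.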

Compound 3, solubility: 50000 nM
For compound 3 the middle estimate is 1.6-fold (0.20 log units) above the measured one, and the stated range covers the measured number.
By their numbers in this assay, from the lowest: compounds 1, 3 and 2 (each within the scatter of the next).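

Placing pyridin-3-yl in place of pyridin-2-yl on the carbonyl carbon gives a 2.0-fold lower number from compound 2 to compound 3 (0.30 log units; within the scatter) in this assay, the first reading of a swap between two pyridinyl isomers at this position, and it does not leave the scatter. Placing pyridin-3-yl in place of 4-(dimethylamino)phenyl gives no change at the digits printed from compound 1 to compound 3 (within the scatter), so with the earlier step all three groups on this carbonyl carbon lie within the scatter of one another, and the series as shown offers no measurable separation between a substituted phenyl and either pyridinyl. No supporting data bear on the reason for these readings.

Still open, going by these compounds, is whether any group on this carbonyl carbon can move the number in this assay beyond the scatter, for instance pyridin-4-yl, a saturated ring carrying an amine such as piperidin-4-yl, or a phenyl bearing a carboxylic acid. Equally open, on these data alone, is how far the number would shift with a change elsewhere on the shared core, such as a nitrile in place of the trifluoromethyl group, since all three compounds carry the same core.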